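Chloro for methyl on the aryl ketone of compound 2

The source may hold more compounds than are shown below. What is called first, only, known or untested is meant among the compounds shown, and "the series" means these compounds.

Two members of this series have numbers in a functional assay on KB cells (Homo sapiens) for cytotoxicity, read by sulforhodamine B assay, with a stated time of 48 h; on this read-out lower numbers stand for stronger inhibition and higher numbers for weaker inhibition. Compound 1 `CCC(C)c1cc(/C=C/C(=O)c2ccccc2)cc2cc(C(=O)OC)c(=O)oc12` gives 13400 nM, and compound 2 `CCOC(=O)c1cc2cc(/C=C/C(=O)c3ccc(C)cc3)cc(C(C)CC)c2oc1=O` gives 18000 nM in this assay. The two numbers lie within the scatter of each other, so nothing separates compound 2 from compound 1 on this read-out; both sit in the same region.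

Compound 3 `CCOC(=O)c1cc2cc(/C=C/C(=O)c3ccc(Cl)cc3)cc(C(C)CC)c2oc1=O` has not yet been measured in this assay. It differs from compound 2 in one place: chloro in place of methyl on an aromatic carbon, on an aromatic carbon of a six-membered aromatic ring of carbon only, para to a large group. Seen one bond further out, the 4-methylphenyl of compound 2 becomes 4-chlorophenyl in compound 3.

For the measured compounds named here, no pair of measured compounds shows what this exchange does here, so the step has to be judged from the lone pair of values, which themselves hardly differ. The expectation is a step from compound 2 to compound 3 of a 1.3-fold lower number from compound 2 to compound 3 (0.11 log units; within the scatter), not clearly beyond the scatter in either direction. Compound 3 is estimated at 14000 nM in this assay, with a range from 6000 nM to 35000 nM.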

Compound 3, half-maximal inhibitory concentration: 14300 nM
The estimate for compound 3 lay 1.0-fold (0.01 log units) below the measured number; the measured number falls inside the stated range.
By their numbers in this assay, from the lowest: compounds 1, 3 and 2 (each within the scatter of the next).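

In this assay, the exchange of 4-methylphenyl for 4-chlorophenyl on the aryl ketone gives a 1.3-fold lower number from compound 2 to compound 3 (0.10 log units; within the scatter), so at this position the two groups cannot be told apart on this read-out. For the compounds shown here, this is the first comparison that isolates a single place, as compound 1 and compound 2 differ in both the ester and the aryl ketone and so gave no step. No measurement bearing on this result accompanies the numbers, and the reading therefore stays purely descriptive.

Still open, on these data alone, is how far this tolerance extends on the aryl ring: methyl and chloro are single-atom groups, and an amine, a carboxylic acid or a longer chain at the same place could read quite differently from compound 2 and compound 3. Also open is what the ester contributes on its own, with a methyl ester in compound 1 and an ethyl ester in compound 2 and compound 3, as a one-place comparison of the two esters on the same aryl ketone is absent from the compounds shown.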